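This account rests on a few compounds, and the source may have more. Where it says the series, first, only, none or still open, it means among the compounds named here.

Working notes on the series. Compound 1 `COc1cccc(C(=N)Nc2cc(C(=O)Nc3cc(C(=O)Nc4cc(C(=O)NCCCN(C)C)n(C)c4)n(C)c3)n(C)c2)c1` gives 11 degrees C in an assay on nucleic acid for binding affinity to Salmon testes DNA (Salmonidae), tested at 10 uM; a lower number here means that the compound stabilises the target less, a higher number that the compound stabilises the target more against heat. Compound 2 `CN(C)CCCNC(=O)c1cc(NC(=O)c2cc(NC(=O)c3cc(NC(=N)c4ccccc4)cn3C)cn2C)cn1C` gives 11 degrees C in this assay, and no change at the digits printed from compound 1 to compound 2 (within the scatter). Compound 3 `CC(C)CCn1cc(NC(=O)c2cc(NC(=O)c3cc(NC(=N)c4ccccc4)cn3C)cn2C)cc1C(=O)NCCCN(C)C` gives 8 degrees C in this assay, where a number 3.0 degrees C lower from compound 2 to compound 3 (beyond the scatter). Compound 3 thus holds the lowest of the three numbers, with compound 1 and compound 2 each standing the same distance above it, beyond the scatter.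

Compound 4 `COc1cccc(C(=N)Nc2cc(C(=O)Nc3cc(C(=O)Nc4cc(C(=O)NCCCN(C)C)n(CCC(C)C)c4)n(C)c3)n(C)c2)c1` is not yet measured. Its change from compound 3 is methoxy in place of hydrogen on an aromatic carbon. For the measured compounds named here, the one measured step that bears on this is the same exchange run the other way, on the core carrying the shorter chain on the ring nitrogen, where no change at the digits printed from compound 1 to compound 2 (within the scatter). The step between compound 2 and compound 3 concerns the isobutyl chain and is not informative here. On that basis no step beyond the scatter is expected in this assay from compound 3 to compound 4, and the expected step is no change at the digits printed from compound 3 to compound 4 (within the scatter). Compound 4 is therefore estimated to give 8 degrees C in this assay, within a range from 6 degrees C to 10 degrees C.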

Compound 4, shift of the target's melting temperature: 5 degrees C
Compound 4: the middle estimate sits 3.0 degrees C above what was measured; measured number outside the range, below it.
By their numbers in this assay, from the lowest: compound 4; then compound 3; then compounds 1 and 2 (each within the scatter of the next).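

On the core carrying the isobutyl chain, phenyl to 3-methoxyphenyl is not silent as it was on the other core, giving a number 3.0 degrees C lower from compound 3 to compound 4 (beyond the scatter) in this assay, so the reading of this exchange depends on the core: the same change on two cores in this assay, no change at the digits printed (within the scatter) from compound 1 to compound 2 and a number 3.0 degrees C higher (beyond the scatter) from compound 4 to compound 3, 3.0 degrees C apart, beyond the scatter of two such steps

Read from the other side, the isobutyl change weighs more where the 3-methoxyphenyl is present, with a number 6.0 degrees C lower from compound 1 to compound 4 (beyond the scatter), so the two changes do not add independently: the same change on two cores in this assay, a number 3.0 degrees C lower (beyond the scatter) from compound 2 to compound 3 and a number 6.0 degrees C lower (beyond the scatter) from compound 1 to compound 4, 3.0 degrees C apart, beyond the scatter of two such steps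

Among these four compounds, the methoxy goes with a lower number only in the presence of the isobutyl chain.

The compounds shown leave open whether this coupling is specific to methoxy or would also appear with a hydroxy, a fluorine or a methyl in its place. They also leave open how it runs with a longer chain on the ring nitrogen or with methoxy elsewhere on the six-membered ring.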